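Replacing the aromatic ring at the enone carbon of compound 2

This account rests on a few compounds, and the source may have more. Where it says the series, first, only, none or still open, it means among the compounds named here.

Measured compounds:
compound 1 `C[C@@H](O[C@H]1CN2C(=O)C=C(c3ccc(C#N)cc3)CC2[C@@H]1c1ccc(F)cc1)c1cc(C(F)(F)F)cc(C(F)(F)F)c1`: 1.8 nM
compound 2 `C[C@@H](O[C@H]1CN2C(=O)C=C(c3cc[n+]([O-])cc3)CC2[C@@H]1c1ccc(F)cc1)c1cc(C(F)(F)F)cc(C(F)(F)F)c1`: 0.1 nM
compound 3 `CCc1noc(C2=CC(=O)N3C[C@H](O[C@H](C)c4cc(C(F)(F)F)cc(C(F)(F)F)c4)[C@@H](c4ccc(F)cc4)C3C2)n1`: 0.4 nM

Of the compounds shown here, three sharing one core have been tested in an assay on CHO cells for displacement of a labelled ligand from Substance-P receptor (Homo sapiens); on this read-out lower numbers stand for stronger inhibition and higher numbers for weaker inhibition. Compound 2 gives the lowest number of the three: compound 3 comes nearest, with a 4.0-fold higher number from compound 2 to compound 3 (0.60 log units; beyond the scatter), and compound 1 lies furthest, with an 18-fold lower number from compound 1 to compound 2 (1.26 log units; beyond the scatter) separating the two. Both steps at this position are beyond the scatter, so the group on the double-bonded ring carbon clearly matters.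

Compound 4 `C[C@@H](O[C@H]1CN2C(=O)C=C(C3=CCC(O)CC3)CC2[C@@H]1c1ccc(F)cc1)c1cc(C(F)(F)F)cc(C(F)(F)F)c1` is not yet measured. It differs from compound 2 by a group of 7 heavy atoms (6 carbon, 1 oxygen; one six-membered non-aromatic ring of carbon only) in place of a group of 7 heavy atoms (5 carbon, 1 nitrogen, 1 oxygen; one six-membered aromatic ring with 1 hetero atom), on a double-bonded ring carbon. The measured steps that bear on it are the exchange of the cyanophenyl for the six-membered heteroaromatic ring, which was large, and the exchange of that ring for the five-membered heteroaromatic ring, which was modest. Among the compounds with values here, compound 4 keeps a single hydrogen-bond acceptor but adds a donor and gives up aromaticity, a change for which no direct precedent exists among the three. A modest rise in the number relative to compound 2 is therefore expected in this assay, comparable to the step to compound 3. The estimated step is a 5.0-fold higher number from compound 2 to compound 4 (0.70 log units; beyond the scatter), expected to remain beyond the scatter. For compound 4 the expected value is 0.5 nM, with a range from 0.1 nM to 2.5 nM.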

Compound 4, half-maximal inhibitory concentration: 0.18 nM
Compound 4: the middle estimate sits 2.8-fold (0.44 log units) above what was measured; the range from low to high includes it.
By their numbers in this assay, from the lowest: compounds 2 and 4 (each within the scatter of the next); then compound 3; then compound 1.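

In this assay, the step of a 1.8-fold higher number from compound 2 to compound 4 (0.26 log units; within the scatter) shows that an aromatic ring and a ring nitrogen are not required at this double-bonded ring carbon: the non-aromatic, all-carbon 4-hydroxycyclohex-1-en-1-yl, which brings a hydrogen-bond donor, stays within the scatter of the group it replaces. The same group also stands clear of the two other groups at this position, with a 2.2-fold lower number from compound 3 to compound 4 (0.35 log units; beyond the scatter) against the 3-ethyl-1,2,4-oxadiazol-5-yl and a 10-fold lower number from compound 1 to compound 4 (1.00 log units; beyond the scatter) against the 4-cyanophenyl, so among these four compounds the 4-cyanophenyl is the one that stands apart on the weak side. No measurement is at hand that would explain this result.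

On these data alone, it remains open what the hydroxyl itself contributes, as the response of this read-out to a plain cyclohexenyl ring, or to an amine or a carboxylic acid in place of the hydroxyl, is unknown. The compounds shown also cannot separate the role of the ring double bond from that of the hydroxyl, as both enter together in compound 4.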